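This account rests on a few compounds, and the source may have more. Where it says the series, first, only, none or still open, it means among the compounds named here.

Of the compounds shown here, three have been tested in a functional assay on the whole organism (strain Wistar albino) for inhibition, with Rattus norvegicus as the target, read by paw edema, with stated times of 30 min and 2 h, at a dose of 20 mg/kg; a higher number here means more inhibition at the dose given (going by the name of the read-out), a lower number less inhibition. Compound 1 `Cc1ccc([C@H]2CC(c3ccccc3)=NN2c2ncc(Br)cn2)cc1` gives 69%, compound 2 `Clc1ccc([C@H]2CC(c3ccccc3)=NN2c2ncc(Br)cn2)cc1` gives 76%, and compound 3 `COc1ccc([C@H]2CC(c3ccc(Cl)cc3)=NN2c2ncc(Br)cn2)cc1` gives 70%. Among these three numbers compound 3 stands second highest; its nearest neighbour is compound 1, whose value lies within the scatter of compound 3, and its furthest is compound 2, whose value also lies within the scatter. Within the data shown here, the only step between two measured compounds that differ in one place is a number 7 percentage points higher from compound 1 to compound 2 (within the scatter), an exchange of one small group for another on the outer ring.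

Compound 4 `Clc1ccc(C2=NN(c3ncc(Br)cn3)[C@@H](c3ccccc3)C2)cc1` has not yet been measured. It differs from compound 3 in a single place: hydrogen in place of methoxy on an aromatic carbon. Among the measured compounds shown here, no measured pair carries this same exchange, so there is no direct precedent. For the measured compounds named here, the one step that does exist, from compound 1 to compound 2, swapped groups on the same kind of ring and stayed within the scatter, which suggests that changes of this sort have little effect in this assay. Compound 4 is therefore expected to sit close to compound 3, with an expected step of no change at the digits printed from compound 3 to compound 4 (within the scatter). The estimate for compound 4 is 70%, with a range from 60% to 80%.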

Compound 4, a percentage reported as inhibition, in the whole organism at one dose (the size of the read-out at that dose, not a potency): 73%
Beside the measured number, compound 4's estimate is 3 percentage points below it; low and high end bracket the measured number.
By their numbers in this assay, from the lowest: compounds 1, 3, 4 and 2 (each within the scatter of the next).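

In this assay, going from 4-methoxyphenyl to phenyl gives a number 3 percentage points higher from compound 3 to compound 4 (within the scatter) and so shows that, in this pair, the methoxy group, with its two heavy atoms and its hydrogen-bond acceptor, can give way to a bare hydrogen without a step beyond the scatter. The earlier compounds all carried a group at this place on the ring, para to a large group, so this is the first compound shown with only hydrogen there, and the read-out at this dose does not depend on a group being present in this pair. No measurement shown here offers an explanation for this result.

The step is one pair at a single dose, so it gives no potency and cannot show whether a group at this place could shift the read-out beyond the scatter in either direction. What a primary amine, a carboxylic acid or a longer chain such as butoxy would do at this place stays open, since every group shown here is small and uncharged.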